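The compounds below may be only part of what the source reports. "The series", "measured", "known", "first", "only" and "open" are said of these compounds alone.

Measured so far in a functional assay on the whole organism (plasma, strain Sprague-Dawley) with Rattus norvegicus as the target, with a stated time of 2 h, at a dose of 100 mg/kg by the oral route; on this read-out higher numbers stand for a stronger effect at the one dose given and lower numbers for a weaker effect:
compound 1 `Cc1ccc(C(/N=C2\CCCCCN2)C2CC2)c(C)c1` gives 56%;
compound 2 `c1ccc(C(/N=C2\CCCCCN2)C2CCCC2)cc1` gives 46%;
compound 3 `c1ccc(C(/N=C2\CCCCCN2)C2CCCCCC2)cc1` gives 6%.

Compound 3 stands lowest of these three numbers. Its nearest neighbour is compound 2, and compound 1 lies furthest from it; both gaps are beyond the usual scatter. Compound 1 and compound 2 differ from each other in more than one place, and their two values lie within the scatter of each other, so nothing about order can be read from that pair.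

Compound 4 `c1ccc(C(/N=C2\CCCCCN2)c2cccs2)cc1` has not yet been measured. It differs from compound 3 in a single place: thiophen-2-yl in place of cycloheptyl on a saturated chain carbon bound to an aromatic carbon and a double-bonded nitrogen

Within the data shown here, one measured step touches the same position. Going a number 40 percentage points lower from compound 2 to compound 3 (beyond the scatter). That step replaced a smaller saturated ring with the cycloheptyl that compound 4 now gives up, so it points, if anything, towards a recovery when cycloheptyl leaves. Among the measured compounds shown here, no measured compound carries thiophen-2-yl or any aromatic ring at this carbon, so the direction is only loosely supported and the expected change is wide. Compound 4 is therefore expected to rise by a number 32 percentage points higher from compound 3 to compound 4 (beyond the scatter), with an estimated value of 38%, between 12% and 65%.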

Compound 4, a percentage reported as inhibition, in the whole organism at one dose (the size of the read-out at that dose, not a potency): 50%
The estimate for compound 4 lay 12 percentage points below the measured number; low and high end bracket the measured number.
By their numbers in this assay, from the lowest: compound 3; then compounds 2, 4 and 1 (each within the scatter of the next).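

Among these compounds, until now only saturated rings had stood on this carbon, so thiophen-2-yl is the first aromatic ring seen there in this assay. The result shows that the weak effect of compound 3 is not a fixed feature of the position, with a number 44 percentage points higher from compound 3 to compound 4 (beyond the scatter) when cycloheptyl gives way to this ring, while a number 4 percentage points higher from compound 2 to compound 4 (within the scatter) means that an aromatic ring containing sulfur and the saturated cyclopentyl cannot be told apart here. No measurement at hand accounts for the low value of the cycloheptyl compound or for the recovery.

The compounds shown leave open whether the sulfur atom of thiophen-2-yl matters at all, a question that a plain phenyl ring or a furan-2-yl group on the same carbon would bear on. They also leave open how cyclohexyl, the saturated ring lying in size between cyclopentyl and cycloheptyl, would behave, and so whether the drop seen with cycloheptyl sets in gradually or only at the largest ring.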